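The source may hold more compounds than are shown below. What is called first, only, known or untested is meant among the compounds shown, and "the series" means these compounds.

Compound 1 `CCCCn1cc(C(=O)C(=O)Nc2ccc(OC)nc2)c2ccccc21` carries a butyl group on the aromatic nitrogen of its fused core. Within the data shown here, in a functional assay on FaDu cells (Homo sapiens) for cytotoxicity, read by MTT assay, with a stated time of 72 h (a lower number here means that less compound is tolerated, a higher number that more compound is tolerated), compound 1 gives 18 nM, and that is the only plain number among the values shown. Among the measured compounds shown here, compound 2 `COc1ccc2c(c1)c(C(=O)C(=O)Nc1ccc(OC)nc1)cn2C(C)C` differs from compound 1 in two places at once, so no single step connects the two. In this assay compound 2 reaches only a limit of the method, > 10000 nM. That limit, (the limit of > 10000 nM in this assay, at which 1 of the 2 values shown sits), is the other value shown, and nothing more can be read from it. Compound 3 `COc1ccc(NC(=O)C(=O)c2cn(C(C)(C)COCC(=O)O)c3ccccc23)cn1` has not yet been measured. It differs from compound 1 by one change: a group of 9 heavy atoms (6 carbon, 3 oxygen; no ring) in place of a group of 4 heavy atoms (4 carbon; no ring), on an aromatic nitrogen. For the measured compounds named here, no measured pair here shows what such a change does, so the expectation rests on the size of the group alone. The step from compound 1 to compound 3 in this assay is expected to be a loss, a 22-fold higher number from compound 1 to compound 3 (1.35 log units; beyond the scatter), larger than the usual scatter. Compound 3 is therefore estimated to give about 400 nM, with a plausible range from 40 nM to 5000 nM.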

Compound 3, concentration lethal to 50% of the cells: > 10000 nM
Compound 3 was reported as a limit; the forecaster's own chance of this, stated with the estimate: 20%; middle value at least 25-fold (1.39 log units) from the limit.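

Among these compounds, this is the first pair here that differs in one place only, so a change on the aromatic nitrogen can now be read by itself: replacing butyl with the group of 9 heavy atoms gives an at least 550-fold higher number from compound 1 to compound 3 (2.74 log units; beyond the scatter) in this assay. The nitrogen is therefore not a place where any group can be swapped in freely, since this single change, with the rest of compound 1 kept, is enough to lose its low value. Compound 3 stands at a limit of the assay, so the step has a lower bound but no exact size: the limit of > 10000 nM in this assay, at which 2 of the 3 values shown sit.

The change alters several things at once, namely the size of the group, its oxygen atoms and its hydrogen-bond donor and acceptors, and this one pair cannot tell which of them matters. The compounds shown also leave open what a longer plain chain such as hexyl, or a chain ending in an amine, would do at this nitrogen. No compound shown separates the size of the group from its other features.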